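Benzyl for Propargyl on a Second Carbamate Core

The source may report more compounds than this note shows. Statements on the series, on what has been measured and on what is new or still open speak of the compounds shown alone.

Compound 1 `C#CCN1CCC(OC(=O)Nc2ccc(C(C)C)cc2)CC1` carries a propargyl group on its ring nitrogen. In an assay on BTI-TN-5B1-4 cells for inhibition of Amine oxidase [flavin-containing] B (Homo sapiens), read by fluorescence and Amplex Red, using microsomes, with a stated time of 15 min (a lower number here means a stronger inhibitor, a higher number a weaker inhibitor), compound 1 gives 178 nM. Compound 3 `CC(C)c1ccc(NC(=O)OC2CCN(Cc3ccccc3)CC2)cc1` differs from it by phenyl in place of ethynyl on a saturated chain carbon bound to an amine nitrogen in a ring. In this assay compound 3 reaches only a limit of the assay, > 100000 nM. The step of an at least 560-fold higher number from compound 1 to compound 3 (2.74 log units; beyond the scatter) is therefore known only as a floor, since its end point sits at the limit of > 100000 nM in this assay, at which 1 of the 3 values shown sits.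

Compound 2 `C#CCN1CCCC(COC(=O)Nc2ccc(C(C)C)cc2)C1` keeps the propargyl group on a different core; the difference between the two cores is not broken down here. In this assay compound 2 gives 2860 nM, the higher of the two numbers measured, above compound 1 by a margin beyond the scatter. Compound 4 `CC(C)c1ccc(NC(=O)OCC2CCCN(Cc3ccccc3)C2)cc1` has not yet been measured. It differs from compound 2 by phenyl in place of ethynyl on a saturated chain carbon bound to an amine nitrogen in a ring, and since the place is described in the same words as for the earlier pair, the change is the same one, now made on the core of compound 2.

With a single earlier occurrence to go on, one expects the step of a 70-fold higher number from compound 2 to compound 4 (1.84 log units; beyond the scatter) in this assay to be large, resting on an at least 560-fold higher number from compound 1 to compound 3 (2.74 log units; beyond the scatter), which already starts from a lower number than compound 2 and still ends at the assay limit. For compound 4 the estimate in this assay is 200000 nM, expected to fall between 40000 nM and 1000000 nM, with a strong chance that the assay again reports only a limit rather than a number.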

Compound 4, half-maximal inhibitory concentration: > 100000 nM
Compound 4 gave a limit, no number; the forecaster's own chance of this, stated with the estimate: 85%; the middle value is on the limit's open side.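

On the core of compound 2, the change from propargyl to benzyl gives an at least 34-fold higher number from compound 2 to compound 4 (1.54 log units; beyond the scatter) in this assay, so the number rises on this core as it did on the core of compound 1, and the step is large on both. In this assay compound 4 gives > 100000 nM, which is a limit of the assay and not a number, so the step to it is known only as a floor. The two compounds with the propargyl group start from clearly different numbers, but this does not show whether the change costs the same on both cores or more on one of them: the same change on two cores in this assay, an at least 560-fold higher number (2.74 log units; beyond the scatter) from compound 1 to compound 3 and an at least 34-fold higher number (1.54 log units; beyond the scatter) from compound 2 to compound 4; the limit leaves it open whether they differ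

The compounds shown leave open what other groups at this place on the amine nitrogen in a ring would give, such as a methyl, an allyl or a phenylethyl chain, or a benzyl carrying a fluorine or a methoxy on its ring. They also leave open how far past the limit the two benzyl compounds lie, since neither has a number of its own: the limit of > 100000 nM in this assay, at which 2 of the 4 values shown sit.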